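The compounds below may be only part of what the source reports. "The series", "measured", "known", "first", "only" and "open" are said of these compounds alone.

Measured so far in an in vivo functional assay on the whole organism for inhibition, with Rattus norvegicus as the target; on this read-out higher numbers stand for an effect only at larger amounts of compound and lower numbers for an effect already at smaller amounts:
- compound 1 `CCCCc1nc(C)c(CCC(=O)OCC)c(=O)n1Cc1ccc(-c2ccccc2-c2nnn[nH]2)cc1` gives 0.066 mg/kg
- compound 2 `CCCCc1nc(C)c(CC(=O)N2CCOCC2)c(=O)n1Cc1ccc(-c2ccccc2-c2nnn[nH]2)cc1` gives 0.018 mg/kg

Compound 2 has the lower of these two numbers, so its effect appears at the smaller dose. Compound 3 `CCCCc1nc(C)c(CC(=O)N2CC(C)OC(C)C2)c(=O)n1Cc1ccc(-c2ccccc2-c2nnn[nH]2)cc1` changes it in one place: 2,6-dimethylmorpholin-4-yl in place of morpholin-4-yl on a carbonyl carbon. In words, 2,6-dimethylmorpholin-4-yl stands in place of morpholin-4-yl on a carbonyl carbon. Among the measured compounds shown here, the only measured step that bears on this is modest, a 3.7-fold lower number from compound 1 to compound 2 (0.56 log units; beyond the scatter). For the measured compounds named here, it shows that the value can move with a change in this part of the molecule, yet no measured compound carries 2,6-dimethylmorpholin-4-yl. A shift beyond the scatter in this assay is therefore not expected, in either direction. The expected step is a 1.4-fold higher number from compound 2 to compound 3 (0.14 log units; within the scatter). The estimate for compound 3 is 0.025 mg/kg, with an expected range of 0.008 mg/kg to 0.08 mg/kg.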

Compound 3, dose for half-maximal effect: 0.029 mg/kg
For compound 3 the middle estimate is 1.2-fold (0.06 log units) below the measured one, within the range that was stated.
By their numbers in this assay, from the lowest: compounds 2 and 3 (each within the scatter of the next); then compound 1.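

The step to 2,6-dimethylmorpholin-4-yl on the carbonyl carbon is a 1.6-fold higher number from compound 2 to compound 3 (0.21 log units; within the scatter), so in this assay this place accepts a group of 8 heavy atoms in place of one of 6 without a shift beyond the scatter. The lower number relative to compound 1 also remains, as a 2.3-fold lower number from compound 1 to compound 3 (0.36 log units; beyond the scatter). Nothing available explains these numbers.

The compounds shown leave open how a piperazin-1-yl ring or an open-chain dimethylamino group on the same carbonyl carbon would read. They also leave open whether a still larger group, such as 4-phenylpiperidin-1-yl, would be accepted there.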